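The source may report more compounds than this note shows. Statements on the series, on what has been measured and on what is new or still open speak of the compounds shown alone.

Values in a functional assay on HCT-116 cells (Homo sapiens) for cytotoxicity, with a stated time of 3 days; a lower number here means a stronger inhibitor, a higher number a weaker inhibitor:
- Compound 1 `C=Cc1nc2ccccc2s1`: > 40000 nM (a limit)
- Compound 2 `C#Cc1nc2ccccc2s1`: 19600 nM
- Compound 3 `C#Cc1nc(/C=C/C(=O)Nc2ccc(Cl)cc2)cs1`: 23200 nM

The value for compound 1 is a limit, not a number. Among the measured compounds shown here, only two real numbers are therefore available. Compound 2, at 19600 nM, lies within the scatter of compound 3, at 23200 nM, so neither can be ranked ahead of the other.

The next compound, compound 4 `CC#Cc1nc2ccccc2s1`, has methyl in place of hydrogen on a triple-bonded carbon. For the measured compounds named here, one measured step touches this same group: an at least 2.0-fold lower number from compound 1 to compound 2 (0.30 log units; that floor lies within the scatter). That step rests on (the limit of > 40000 nM in this assay, at which 1 of the 3 values shown sits), so it gives a floor rather than a true size, and it is only a loose guide.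

Going by compound 1 at > 40000 nM, any drift is expected to run upward, but no change clearly beyond the scatter is expected. The expected change is a 1.4-fold higher number from compound 2 to compound 4 (0.15 log units; within the scatter). For compound 4 the estimated value is 28000 nM, with an expected range from 13000 nM to 50000 nM.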

Compound 4, half-maximal inhibitory concentration: > 40000 nM
Compound 4: only a limit was reported; the forecaster's own chance of this, stated with the estimate: 40%; at least 1.4-fold (0.15 log units) between middle value and limit.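

Among the compounds shown here, putting methyl in place of hydrogen on a triple-bonded carbon gives an at least 2.0-fold higher number from compound 2 to compound 4 (0.30 log units; that floor lies within the scatter), the first information on a change at the end of the triple bond itself, since the earlier step only swapped vinyl for ethynyl. In this assay compound 4 gives > 40000 nM, which is a limit and not a number, so this step is only a floor and the real change could be small or large. The step from compound 1 to compound 4 cannot be read, and the size of the methyl step stays unknown because two values now rest on the same limit: the limit of > 40000 nM in this assay, at which 2 of the 4 values shown sit.

As far as these compounds go, it remains open whether an amine or a longer chain at this triple-bonded carbon would give a readable value. Also open, from the compounds shown here alone, is whether methyl would act the same way on the core of compound 3, which carries the same ethynyl group.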